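This account rests on a few compounds, and the source may have more. Where it says the series, first, only, none or still open, it means among the compounds named here.

Three compounds share one core and differ in a single ring group: compound 1 (`COc1ccc(/C=C2\CCC/C(=C\c3cccc(Cl)c3)C2=O)cc1OC`), compound 2 (`COc1ccc(/C=C2\CCC/C(=C\c3ccc(Cl)cc3)C2=O)cc1OC`) and compound 3 (`COc1ccc(/C=C2\CCC/C(=C\c3ccc(Br)cc3)C2=O)cc1OC`). In a functional assay on MCF7 cells (Homo sapiens) for cytotoxicity, read by MTT assay, with a stated time of 72 h (on this read-out lower numbers stand for stronger inhibition and higher numbers for weaker inhibition), compound 1 gives 6000 nM while compound 2 gives 6300 nM and compound 3 gives 6900 nM in the same test. Compound 3 thus stands level with the other two, as its gaps to both lie within the usual scatter.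

The next structure is compound 4 (`COc1cccc(/C=C2\CCC/C(=C\c3ccc(OC)c(OC)c3)C2=O)c1`). The change from compound 3 is 3-methoxyphenyl in place of 4-bromophenyl on a double-bonded chain carbon bound to a double-bonded ring carbon with 3-methoxyphenyl in place of 4-bromophenyl on a double-bonded chain carbon bound to a double-bonded ring carbon. The measured swaps at this place were all small, and they show a 1.2-fold higher number from compound 1 to compound 3 (0.06 log units; within the scatter) for one swap, a 1.1-fold higher number from compound 1 to compound 2 (0.02 log units; within the scatter) for another and a 1.1-fold higher number from compound 2 to compound 3 (0.04 log units; within the scatter) for bromo in place of chloro on an aromatic carbon. Going by the values given here, no measured compound carries 3-methoxyphenyl at this place, so these steps are only indirect guides.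

With steps as small as a 1.2-fold higher number from compound 1 to compound 3 (0.06 log units; within the scatter) on record, no step beyond the scatter is expected in this assay in either direction. The estimate therefore means a 1.1-fold lower number from compound 3 to compound 4 (0.03 log units; within the scatter) and nothing larger. For compound 4 the estimated value is 6500 nM with 2800 nM to 15000 nM as the expected span.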

Compound 4, half-maximal inhibitory concentration: 4600 nM
Compound 4: middle estimate off by 1.4-fold (0.15 log units), on the high side; low and high end bracket the measured number.
By their numbers in this assay, from the lowest: compounds 4, 1, 2 and 3 (each within the scatter of the next).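

Putting 3-methoxyphenyl at this place, on a double-bonded chain carbon bound to a double-bonded ring carbon, gives the only ring here that carries oxygen instead of a halogen, yet in this assay the result stays within the usual scatter against all three halogen compounds: a 1.5-fold lower number from compound 3 to compound 4 (0.18 log units; within the scatter), a 1.4-fold lower number from compound 2 to compound 4 (0.14 log units; within the scatter), and a 1.3-fold lower number from compound 1 to compound 4 (0.12 log units; within the scatter). The earlier compounds shown here compared only chloro and bromo rings, whereas these steps extend the flat picture to a group that brings one hydrogen-bond acceptor and one more heavy atom, and neither difference separates compound 4 from the others in this test. No outside measurement on these compounds is available to explain this result.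

The compounds shown leave open whether a group of a different kind on this ring, such as an amine or a carboxylic acid, would give a step beyond the scatter. Going by these compounds, all four compounds also share the rest of their structure, so the effect of changing anything other than this one ring remains unknown.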